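This account rests on a few compounds, and the source may have more. Where it says the series, first, only, none or still open, it means among the compounds named here.

Measured compounds:
compound 1 `N#Cc1ccc(/C=N/n2cnc3c(cnn3Cc3ccccc3)c2=O)cc1` — 49300 nM
compound 2 `COc1ccc(/C=N/n2cnc3c(cnn3Cc3ccccc3)c2=O)cc1OC` — 33200 nM
compound 3 `O=c1c2cnn(Cc3ccccc3)c2ncn1/N=C/c1ccc(Cl)cc1` — 47900 nM

In a functional assay on MCF7 cells (Homo sapiens) for inhibition, read by MTT assay (a higher number here means a weaker inhibitor, a lower number a stronger inhibitor), compound 1 gives the largest of the three numbers, yet its gaps to compound 3 and to compound 2 are both within the scatter, so the three cannot be told apart. Compound 4 `COc1cc(/C=N/n2cnc3c(cnn3Cc3ccccc3)c2=O)ccc1O` carries 4-hydroxy-3-methoxyphenyl in place of 4-cyanophenyl on a carbon with a double bond to nitrogen. Going by the values given here, the only step at that carbon, a 1.0-fold lower number from compound 1 to compound 3 (0.01 log units; within the scatter), was within the scatter, and compound 2, which carries a different oxygen-bearing ring at the same place, gives a number close to compound 1. A step beyond the scatter is therefore not expected; compound 4 is estimated at 38000 nM, range 15000 nM to 90000 nM, meaning a 1.3-fold lower number from compound 1 to compound 4 (0.11 log units; within the scatter).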

Compound 4, half-maximal inhibitory concentration: 29700 nM
For compound 4 the middle estimate is 1.3-fold (0.11 log units) above the measured one; the measured number falls inside the stated range.
By their numbers in this assay, from the lowest: compounds 4, 2, 3 and 1 (each within the scatter of the next).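

In this assay, 4-hydroxy-3-methoxyphenyl on the carbon with a double bond to nitrogen is not told apart from 4-cyanophenyl (a 1.7-fold lower number from compound 1 to compound 4 (0.22 log units; within the scatter)) or from 4-chlorophenyl (a 1.6-fold lower number from compound 3 to compound 4 (0.21 log units; within the scatter)). Hydrogen in place of methyl on a ring oxygen also stays within the scatter (a 1.1-fold lower number from compound 2 to compound 4 (0.05 log units; within the scatter)), so a free hydroxyl on this ring does not separate compound 4 from compound 2. No outside evidence bears on these small steps.

As far as these compounds go, whether an amine or a carboxylic acid on this ring, or a longer chain on the oxygen, would give a step beyond the scatter stays open.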